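Working notes: replacing the aminomethyl group in this series

The source may hold more compounds than are shown below. What is called first, only, known or untested is meant among the compounds shown, and "the series" means these compounds.

Compound 1 `COc1ccc(-c2nc(CN)sc2-c2ccc(OC)cc2)cc1` is the reference point. In a functional assay with Oryctolagus cuniculus as the target (a higher number here means a weaker inhibitor, a lower number a stronger inhibitor), compound 1 gives > 100 nM, which is a limit of the assay and not a number. Compound 2 `COc1ccc(-c2nc(C(=O)N3CCN(C(=O)NC(C)C)CC3)sc2-c2ccc(OC)cc2)cc1` gives > 1000 nM in this assay, again a limit. Compound 3 `COc1ccc(-c2nc(/C=C/C(=O)N3CCN(C)CC3)sc2-c2ccc(OC)cc2)cc1` gives > 1000 nM in this assay, also a limit. For the measured compounds named here, compound 1 thus stands at the limit of > 100 nM in this assay, at which 1 of the 3 values shown sits, while the other two stand at the limit of > 1000 nM in this assay, at which 2 of the 3 values shown sit; no measured step between any pair of these three compounds can be stated, and all three values show weak inhibition only.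

Compound 4 `COc1ccc(-c2nc(C3=NNC(=O)CC3)sc2-c2ccc(OC)cc2)cc1` is not yet measured. It differs from compound 1 by a group of 7 heavy atoms (4 carbon, 2 nitrogen, 1 oxygen; one six-membered non-aromatic ring with 2 hetero atoms) in place of a group of 2 heavy atoms (1 carbon, 1 nitrogen; no ring), on an aromatic carbon. Going by the values given here, no measured step guides this change. With every measured value a limit, the expectation in this assay is a step toward weaker inhibition that may well stay within the scatter; the step that the limit leaves unreadable from compound 1 to compound 4 is expected in that direction. Compound 4 is estimated at 3000 nM, with a range from 300 nM to 30000 nM, and a limit rather than a number is the likely report.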

Compound 4, half-maximal inhibitory concentration: > 1000 nM
Compound 4 was reported as a limit; the forecaster's own chance of this, stated with the estimate: 70%; the middle value is on the limit's open side.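

Compound 4 is reported only as a limit and not a number, so no step from compound 1 to compound 4 can be read: the limit of > 1000 nM in this assay, at which 3 of the 4 values shown sit.

The compounds shown leave open whether replacing the aminomethyl group moves inhibition in either direction in this assay.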